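Putting 3-methoxyphenyl on the amide-type nitrogen of compound 3

The compounds below may be only part of what the source reports. "The series", "measured", "known", "first", "only" and "open" are said of these compounds alone.

Measured in a functional assay on A-375 cells (Homo sapiens) for antiproliferative activity, read by MTT assay, with a stated time of 72 h; on this read-out higher numbers stand for weaker inhibition and lower numbers for stronger inhibition:
- compound 1 `COc1ncc(-c2ccc3c(c2)N(c2ccc(C)cc2)C(=O)CO3)cc1NS(=O)(=O)c1ccc(F)cc1`: 12900 nM
- compound 2 `COc1cccc(N2C(=O)COc3ccc(-c4cnc(Cl)c(NS(=O)(=O)c5ccc(F)cc5)c4)cc32)c1`: > 40000 nM (a limit of the assay, not a number)
- compound 3 `COc1ncc(-c2ccc3c(c2)NC(=O)CO3)cc1NS(=O)(=O)c1ccc(F)cc1`: 26300 nM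

Of the two true numbers, the higher belongs to compound 3, so it shows the weaker inhibition. Compound 4 `COc1cccc(N2C(=O)COc3ccc(-c4cnc(OC)c(NS(=O)(=O)c5ccc(F)cc5)c4)cc32)c1` carries one change: 3-methoxyphenyl in place of hydrogen on an amide-type nitrogen in a ring. For the measured compounds named here, one measured step bears on this: a 2.0-fold higher number from compound 1 to compound 3 (0.31 log units; beyond the scatter), where hydrogen replaces 4-methylphenyl on an amide-type nitrogen in a ring. Read in reverse, that modest step suggests that adding a ring there should give a lower number in this assay, by a similar modest size. The expected change is a 1.9-fold lower number from compound 3 to compound 4 (0.27 log units; within the scatter). For compound 4 the estimated value is 14000 nM, with an expected range of 5000 nM to 38000 nM.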

Compound 4, half-maximal inhibitory concentration: > 40000 nM
Compound 4 ended at the assay's limit; the forecaster's own chance of this, stated with the estimate: 20%; middle value at least 2.8-fold (0.45 log units) from the limit.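

In this assay, adding a ring on the amide-type nitrogen does not reliably lower the number: with 3-methoxyphenyl in place of hydrogen, the result is an at least 1.5-fold higher number from compound 3 to compound 4 (0.18 log units; that floor lies within the scatter). Changing only the ring gives an at least 3.1-fold higher number from compound 1 to compound 4 (0.49 log units; beyond the scatter), so at this position the choice of ring matters, not merely its presence. Compound 2 and compound 4 both give a limit of the assay rather than a number, so the step between them cannot be read: the limit of > 40000 nM in this assay, at which 2 of the 4 values shown sit.

Still open, from the compounds shown here alone, is how a methyl group or a longer chain on this nitrogen would behave. It is also unknown whether a phenyl ring carrying an amine would behave like either ring here.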